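This account rests on a few compounds, and the source may have more. Where it says the series, first, only, none or still open, it means among the compounds named here.

Series notes. Compound 2 `Cc1ccc(Oc2ccc(CC3SC(=O)NC3=O)cc2)cc1` and compound 1 `Cc1ccc(Oc2ccc(CC3SC(=O)NC3=O)cc2)cc1C` share a core and differ in one place: methyl in place of hydrogen on an aromatic carbon. In a functional assay for agonist activity at Free fatty acid receptor 1 (Homo sapiens), read by FLIPR, in the presence of a further agent that is not named here (a higher number here means that more compound is needed for the effect, a lower number that less compound is needed), compound 2 gives 547 nM, and compound 1 gives 727 nM; the step is a 1.3-fold higher number from compound 2 to compound 1 (0.12 log units; within the scatter). Compound 3 `O=C1NC(=O)C(Cc2ccc(Oc3cc(C(F)(F)F)ccn3)cc2)S1` carries a different core; the difference between the two cores is not broken down here. In this assay compound 3 gives 237 nM, the lowest of the three numbers, with compound 2 nearest and compound 1 furthest, both gaps beyond the scatter.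

Compound 4 `Cc1cc(C(F)(F)F)cc(Oc2ccc(CC3SC(=O)NC3=O)cc2)n1` is not yet measured. It differs from compound 3 by methyl in place of hydrogen on an aromatic carbon. This is the same kind of change as from compound 2 to compound 1, but not the same: there the methyl entered on a six-membered aromatic ring of carbon only, ortho to a methyl group and meta to a large group; here it enters on a six-membered aromatic ring with 1 nitrogen, next to the ring nitrogen, meta to a large group and meta to a trifluoromethyl group. Going by the values given here, for compound 4 the expected step in this assay is a 1.3-fold higher number from compound 3 to compound 4 (0.10 log units; within the scatter), resting on the single earlier step of a 1.3-fold higher number from compound 2 to compound 1 (0.12 log units; within the scatter), which stayed within the scatter. Compound 4 is expected to give 300 nM in this assay, between 120 nM and 750 nM.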

Compound 4, half-maximal effective concentration: 218 nM
Beside the measured number, compound 4's estimate is 1.4-fold (0.14 log units) above it, within the range that was stated.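

In this assay, methyl in place of hydrogen on an aromatic carbon of the six-membered aromatic ring with 1 nitrogen, next to the ring nitrogen, gives a 1.1-fold lower number from compound 3 to compound 4 (0.04 log units; within the scatter). Set beside the earlier step on the other core, the new step gives no sign that the outcome of this change depends on the core: the same change on two cores in this assay, a 1.3-fold higher number (0.12 log units; within the scatter) from compound 2 to compound 1 and a 1.1-fold lower number (0.04 log units; within the scatter) from compound 3 to compound 4, 1.4-fold (0.16 log units) apart, within the scatter of two such steps. Going by these compounds alone, this rests on only two steps, each at a different place on a different ring and neither beyond the scatter, so it shows that the two results agree in this assay but gives no general rule for carrying methyl to other cores or to other places on these rings.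

The compounds shown leave open whether a group other than methyl at this place, such as an ethyl group, a methoxy group or an amine, would give a step beyond the scatter. Also open, going by these compounds, is what a carboxylic acid in place of the trifluoromethyl group of compound 4 would give in this assay.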